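A few compounds are considered here, and "the series" means these few. Any claim that something is new, unique, unknown or untested is made for them only; others in the source may bear on it.

Compound 1 `O=C(Nc1cccc(-n2cc(-c3ccncc3)c(-c3ccc(Cl)c(O)c3)n2)c1)Nc1ccc(Cl)c(Cl)c1` gives > 32500 nM in a functional assay on PC-3 cells (Homo sapiens) for inhibition, read by sulforhodamine B assay, with a stated time of 48 h (a lower number here means a stronger inhibitor of growth, a higher number a weaker inhibitor of growth), which is a limit of the assay and not a number.
Compound 2 `COc1cc(-c2nn(-c3cccc(NC(=O)Nc4ccc(Cl)c(C(F)(F)F)c4)c3)cc2-c2ccncc2)ccc1Cl` gives 2450 nM in this assay.

Among the compounds with values here, compound 2 thus holds the only numerical value in this assay, the other measurement being a limit. Compound 3 `O=C(Nc1cccc(-n2cc(-c3ccncc3)c(-c3ccc(Cl)c(O)c3)n2)c1)Nc1ccc(Cl)c(C(F)(F)F)c1` differs from compound 2 by hydrogen in place of methyl on an oxygen on an aromatic ring. Within the data shown here, no measured pair isolates this change. The step from compound 2 to compound 3 is expected to weaken growth inhibition, by a 2.9-fold higher number from compound 2 to compound 3 (0.46 log units; beyond the scatter), with the caution that compound 1 sits at the limit of > 32500 nM in this assay, at which 1 of the 2 values shown sits. Compound 3 is therefore estimated at 7000 nM, within 2000 nM to 30000 nM.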

Compound 3, concentration for total growth inhibition: 2200 nM
Estimate against measurement, compound 3: 3.2-fold (0.50 log units) above; the range from low to high includes it.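

Swapping methoxy for hydroxy, from 4-chloro-3-methoxyphenyl to 4-chloro-3-hydroxyphenyl, makes no readable difference in this assay, with a 1.1-fold lower number from compound 2 to compound 3 (0.05 log units; within the scatter), so here the oxygen carries either methyl or hydrogen with the same result. With hydroxy held in place, the trifluoromethyl in place of chloro on an aromatic carbon is the step that matters, with an at least 14-fold lower number from compound 1 to compound 3 (1.16 log units; beyond the scatter). The reading for compound 1 is a limit of the assay and not a number, so the true size of that step stays unknown: the limit of > 32500 nM in this assay, at which 1 of the 3 values shown sits.

Going by these compounds, it remains open whether trifluoromethyl and chloro differ as much with methoxy in place. Also open, on these data alone, is how an ethoxy group or an amine would read at this oxygen position.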